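Bromine position swap on the arylamino group of compound 2

A few compounds are considered here, and "the series" means these few. Any claim that something is new, unique, unknown or untested is made for them only; others in the source may bear on it.

For the measured compounds named here, compound 2 `COc1cc(NC(=O)Nc2cc(Nc3ccc(Br)cc3OC)ncn2)cc(OC)c1` gives 25.7% in a functional assay on NCI-H226 cells (Homo sapiens) for inhibition, read by MTT assay, with a stated time of 48 h, tested at 10 uM (on this read-out lower numbers stand for less inhibition and higher numbers for more inhibition at the one concentration tested (going by the name of the read-out)), the lower of the two numbers measured so far; compound 1 `COc1cc(NC(=O)Nc2cc(Nc3ccc(F)c(Cl)c3)ncn2)cc(OC)c1` gives 36.7%. Going by the values given here, the only measured step, a number 11 percentage points lower from compound 1 to compound 2 (beyond the scatter), exchanged the whole aryl group for another and bears on the present change only loosely, since no measured pair moves the bromine within one ring. Compound 3 `COc1cc(NC(=O)Nc2cc(Nc3cc(Br)ccc3OC)ncn2)cc(OC)c1` differs from compound 2 by 5-bromo-2-methoxyphenyl in place of 4-bromo-2-methoxyphenyl on a nitrogen on an aromatic ring. Among the compounds with values here, with no closer precedent, the expected step is a number 2.3 percentage points higher from compound 2 to compound 3 (within the scatter), not beyond the scatter. Compound 3 is therefore estimated at 28%, within 12% to 45%.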

Compound 3, a percentage reported as inhibition, at one concentration (the size of the read-out at that concentration, not a potency): 42.7%
Beside the measured number, compound 3's estimate is 14.7 percentage points below it; the measured number falls inside the stated range.
By their numbers in this assay, from the lowest: compound 2; then compounds 1 and 3 (each within the scatter of the next).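

In this assay moving the bromine within the ring gives a number 17 percentage points higher from compound 2 to compound 3 (beyond the scatter) and separates 5-bromo-2-methoxyphenyl from 4-bromo-2-methoxyphenyl at this place, with the same atoms in both, which the earlier whole-group exchange could not show. The step of a number 6 percentage points higher from compound 1 to compound 3 (within the scatter) leaves 5-bromo-2-methoxyphenyl and 3-chloro-4-fluorophenyl not told apart. No available evidence accounts for the difference between the two bromine arrangements.

Open, as far as these compounds go, is whether the methoxy group is needed in this arrangement, and whether an amine or a carboxylic acid in place of the bromine on 5-bromo-2-methoxyphenyl holds the number.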